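Amide side chain change from compound 3 to compound 4

This account rests on a few compounds, and the source may have more. Where it says the series, first, only, none or still open, it means among the compounds named here.

In a functional assay on MCF7 cells (Homo sapiens), read by MTT assay, with a stated time of 48 h (a lower number here means a stronger inhibitor, a higher number a weaker inhibitor), compound 1 `CCN(CC)CCNC(=O)c1ccc(C(CC)(CC)c2ccc(OCC(=O)C(C)(C)C)c(C)c2)n1CC` gives 690 nM and compound 2 `CCN(CC)CCCNC(=O)c1ccc(C(CC)(CC)c2ccc(OCC(=O)C(C)(C)C)c(C)c2)n1CC` gives 530 nM as the two diethylamino members of the series. Compound 3 `CCn1c(C(=O)NCCN(C)C)ccc1C(CC)(CC)c1ccc(OCC(O)C(C)(C)C)c(C)c1` stands at 660 nM within the scatter of both, so the three values form a single level with no order among them.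

The next change is (2-cyanoethyl)(methyl)amino in place of (2-(dimethylamino)ethyl)amino on a carbonyl carbon and leads to compound 4 `CCn1c(C(=O)N(C)CCC#N)ccc1C(CC)(CC)c1ccc(OCC(O)C(C)(C)C)c(C)c1` with (2-cyanoethyl)(methyl)amino in place of (2-(dimethylamino)ethyl)amino on a carbonyl carbon.

Among the measured compounds shown here, only one measured step bears on this, and only loosely. The step of a 1.3-fold lower number from compound 1 to compound 2 (0.11 log units; within the scatter) comes from (diethylamino)methyl in place of diethylamino on a saturated chain carbon. That step keeps the diethylamino group, whereas the new change removes the dimethylamino group. For the measured compounds named here, no measured compound carries a nitrile, so the data give no direct size for this replacement.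

A small upward move is expected with low confidence, and the estimated step is a 1.5-fold higher number from compound 3 to compound 4 (0.18 log units; within the scatter) in this assay with no firm expectation that it will clear the scatter. The estimate for compound 4 is 1000 nM with an expected range of 350 nM to 2500 nM in this wide window.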

Compound 4, half-maximal inhibitory concentration: > 50000 nM
Compound 4: no number, only a limit (the forecaster's own chance of this, stated with the estimate: 3%); middle value at least 50-fold (1.69 log units) from the limit.
By their numbers in this assay, from the lowest: compounds 2, 3 and 1 (each within the scatter of the next). At a limit, above all of these: compound 4.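

In this assay, among the compounds shown here, the change on the carbonyl carbon gives the first large step: an at least 75-fold higher number from compound 3 to compound 4 (1.87 log units; beyond the scatter). The earlier side-chain step stayed small, a 1.3-fold lower number from compound 1 to compound 2 (0.11 log units; within the scatter), and both of those compounds keep a terminal diethylamino group and the amide hydrogen, so this position had looked insensitive; compound 4 shows that it is not, at least for this replacement, in which the terminal dimethylamino group and the amide hydrogen are lost and a nitrile enters. For compound 4 the reading is a limit of the assay and not a number: the limit of > 50000 nM in this assay, at which 1 of the 4 values shown sits.

This single step changes the amide hydrogen, the dimethylamino group and the nitrile together, so the compounds shown do not assign the loss to any one of them; a (2-cyanoethyl)amino group or a (2-(dimethylamino)ethyl)(methyl)amino group on the same carbonyl carbon would separate these. Also open, going by these compounds, is whether a different terminal amine, such as a morpholine or a primary amine, would hold the level of compound 3 at 660 nM.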